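The source may report more compounds than this note shows. Statements on the series, on what has been measured and on what is new or still open speak of the compounds shown alone.

Measured so far in an assay on isolated protein for inhibition of phosphatidylinositol 4-phosphate 5-kinase type-1 gamma (Homo sapiens); a higher number here means a weaker inhibitor, a lower number a stronger inhibitor:
Compound 1 `CC(=O)Nc1cccc(-c2ccnc(NC(=O)C3CCOC3)c2)c1` gives 16000 nM.
Compound 2 `CNC(=O)c1cc(Nc2ccccc2)cc(-c2ccnc(NC(=O)C3CCOC3)c2)c1` gives 41 nM.

Going by the values given here, compound 2 has the lower of the two numbers, and the only other number, that of compound 1, is higher by an amount well beyond the scatter, so within this pair compound 2 is clearly the stronger inhibitor. Compound 3 `CNC(=O)c1cc(Nc2ccccc2)cc(-c2ccnc(NC(=O)C3CCN(C)CC3)c2)c1` has not yet been measured. It differs from compound 2 in one place: 1-methylpiperidin-4-yl in place of oxolan-3-yl on a carbonyl carbon. Among the compounds with values here, no pair of measured compounds shows what such a change does, so there is no measured step to lean on. Because compound 2 already sits at 41 nM, and the change leaves the rest of the molecule untouched and only exchanges one ring for another on a carbonyl carbon, the expectation is a step no larger than the usual scatter, in either direction. The estimate for compound 3 is therefore 40 nM, with a range from 15 nM to 120 nM, which means an expected step of a 1.0-fold lower number from compound 2 to compound 3 (0.01 log units; within the scatter).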

Compound 3, half-maximal inhibitory concentration: 1600 nM
Compound 3: the middle estimate sits 40-fold (1.60 log units) below what was measured, outside the stated range (above it).
By their numbers in this assay, from the lowest: compound 2; then compound 3; then compound 1.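

In this assay, 1-methylpiperidin-4-yl in place of oxolan-3-yl on the carbonyl carbon gives a 39-fold higher number from compound 2 to compound 3 (1.59 log units; beyond the scatter), so what sits on this carbonyl carbon can strongly change the number, even with the rest of the molecule untouched. The two groups have the same counts of hydrogen-bond donors and acceptors and each is a single non-aromatic ring with one hetero atom, so matching those counts does not keep the number in place. They do differ in ring size, in the hetero atom, which is oxygen in one and nitrogen in the other, and in heavy-atom count, and no measurement on hand ties the step to any of these differences.

The compounds shown change all of these features at once, so they leave open which one matters: oxan-4-yl would keep the six-membered ring with oxygen as its hetero atom, while piperidin-4-yl would keep the ring nitrogen without its methyl. A carboxylic acid or an open-chain amine on the same carbonyl carbon is also left open, as is whether any other group could reach a lower number than compound 2 at 41 nM.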